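The compounds below may be only part of what the source reports. "The series", "measured", "known", "first", "only" and "open" are said of these compounds alone.

Of the compounds shown here, three built on one shared core have been measured. Compound 1 `CC1(C)[C@H]2CC[C@]1(C)N(Cc1cn(-c3cccc(F)c3)nn1)C(=O)C2` carries a 3-fluorophenyl group on an aromatic nitrogen, compound 2 `CC1(C)[C@H]2CC[C@]1(C)N(Cc1cn(-c3cccc(C#N)c3)nn1)C(=O)C2` a 3-cyanophenyl group, and compound 3 `CC1(C)[C@H]2CC[C@]1(C)N(Cc1cn(-c3ccc(Br)cc3)nn1)C(=O)C2` a 4-bromophenyl group. In a functional assay on PANC-1 cells (Homo sapiens) for inhibition, read by MTT assay, with a stated time of 24 h (on this read-out lower numbers stand for stronger inhibition and higher numbers for weaker inhibition), compound 1 gives 220 nM, compound 2 gives 260 nM, and compound 3 gives 200 nM. The steps between them are small: a 1.2-fold higher number from compound 1 to compound 2 (0.07 log units; within the scatter), a 1.1-fold lower number from compound 1 to compound 3 (0.04 log units; within the scatter) and a 1.3-fold lower number from compound 2 to compound 3 (0.11 log units; within the scatter). Compound 3 thus has the lowest of the three numbers, but every gap to the other two lies within the scatter, so no order can be read from them.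

Compound 4 `Cc1ccccc1-n1cc(CN2C(=O)C[C@@H]3CC[C@@]2(C)C3(C)C)nn1` is the next member. 2-methylphenyl in place of 4-bromophenyl on an aromatic nitrogen The two earlier changes of the group on this aromatic nitrogen, a 1.1-fold lower number from compound 1 to compound 3 (0.04 log units; within the scatter) and a 1.3-fold lower number from compound 2 to compound 3 (0.11 log units; within the scatter), both stayed within the scatter, which suggests that swapping one such aryl group for another does little here. No step beyond the scatter is therefore expected in this assay, in either direction. Compound 4 is estimated to give 230 nM, with a plausible range from 110 nM to 480 nM. This estimate corresponds to an expected 1.2-fold higher number from compound 3 to compound 4 (0.06 log units; within the scatter), a step that is itself expected to remain within the scatter.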

Compound 4, half-maximal inhibitory concentration: 250 nM
The estimate for compound 4 lay 1.1-fold (0.04 log units) below the measured number; the range from low to high includes it.
By their numbers in this assay, from the lowest: compounds 3, 1, 4 and 2 (each within the scatter of the next).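

In this assay the change from 4-bromophenyl to 2-methylphenyl on the aromatic nitrogen gives a 1.3-fold higher number from compound 3 to compound 4 (0.10 log units; within the scatter) and the comparisons with the other two groups give a 1.0-fold lower number from compound 2 to compound 4 (0.02 log units; within the scatter) and a 1.1-fold higher number from compound 1 to compound 4 (0.06 log units; within the scatter) so all four compounds now lie within the scatter of one another. Among the compounds shown here, compound 4 adds something the earlier compounds did not show: an aryl group made of carbon only, with no bromine, fluorine or nitrile, gives a number that cannot be told apart from those of the three earlier compounds, so at this position none of these four groups stands out from the others in this cell read-out. No supporting measurement is available to explain why these groups give such similar numbers.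

From the compounds shown here alone, all four groups are phenyl rings with a single small substituent, so it remains open whether the numbers would stay this close with an amine or a carboxylic acid on the ring, or with a longer alkyl chain in place of the ring. The compounds shown also leave open how much the shared core contributes, since it is the same in all four.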